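The source may report more compounds than this note shows. Statements on the series, on what has been measured and on what is new or still open speak of the compounds shown alone.

Three compounds of one shared core are known by structure: compound 1 `O=c1c2cnn(-c3ccc(F)cc3)c2ncn1CC1(O)CCN(Cc2ccccn2)CC1`, compound 2 `O=c1c2cnn(-c3ccc(F)cc3)c2ncn1CC1(O)CCN(Cc2c(Cl)cccc2Cl)CC1` and compound 3 `O=c1c2cnn(-c3ccc(F)cc3)c2ncn1CC1(O)CCN(Cc2ccc(Cl)cc2Cl)CC1`. For compound 1 the entry in an assay on Sf21 cells for inhibition of ubiquitin carboxyl-terminal hydrolase 7 (Homo sapiens), read by spectrophotometry, with stated times of 30 min and 2 h (on this read-out lower numbers stand for stronger inhibition and higher numbers for weaker inhibition), reads "not determined" (no result reported), and for compound 2 it reads "not determined" (no result reported), so neither carries a number. In this assay, among the compounds with values here, compound 3 gives 3300 nM, the only number in the set, and therefore it stands alone with nothing to rank against.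

Compound 4 `COC(=O)c1ccc(CN2CCC(O)(Cn3cnc4c(cnn4-c4ccc(F)cc4)c3=O)CC2)c(F)c1` is the next compound, not yet measured. It differs from compound 3 in one place: 2-fluoro-4-(methoxycarbonyl)phenyl in place of 2,4-dichlorophenyl on a saturated chain carbon bound to an amine nitrogen in a ring. Within the data shown here, no measured pair shows this kind of change, so the direction of the step is unsupported by data. With no comparison available, the expectation is a step from compound 3 to compound 4 of a 1.1-fold lower number from compound 3 to compound 4 (0.04 log units; within the scatter), that is no change beyond the usual scatter. Going by these compounds, compound 4 is therefore estimated at 3000 nM, with a range from 800 nM to 12000 nM, the width reflecting that the change is untested.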

Compound 4, half-maximal inhibitory concentration: 800 nM
Beside the measured number, compound 4's estimate is 3.8-fold (0.57 log units) above it, and the stated range covers the measured number.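

The aromatic group on a saturated chain carbon bound to an amine nitrogen in a ring now has a measured effect: in this assay the change from 2,4-dichlorophenyl to 2-fluoro-4-(methoxycarbonyl)phenyl gives a 4.1-fold lower number from compound 3 to compound 4 (0.62 log units; beyond the scatter). Neither chlorine is therefore needed for inhibition at this level, and the larger group with its methoxycarbonyl is accepted at this place. No measurement available here accounts for the step, and as the two groups differ in more than one feature, it cannot be assigned to any one of them.

Compound 1 and compound 2 carry no number, so their steps cannot be read. Going by these compounds, it stays open how the methoxycarbonyl and the fluorine each contribute, and whether a carboxylic acid or a primary amide in place of the methoxycarbonyl would keep the lower number.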